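A few compounds are considered here, and "the series" means these few. Any claim that something is new, unique, unknown or untested is made for them only; others in the source may bear on it.

Of the compounds shown here, two sharing one core have so far been tested in a functional assay on Huh-7 cells (Homo sapiens) for cytotoxicity, with a stated time of 48 h; a higher number here means a weaker inhibitor, a lower number a stronger inhibitor. Compound 1 `O=[N+]([O-])c1ccc(CN2CCC(n3cc(CC(OCc4cc(-c5ccccc5)no4)c4ccc(Br)cc4)nn3)CC2)cc1` gives 7000 nM. Compound 2 `O=[N+]([O-])c1ccc(CN2CCC(n3cc(CC(OCc4cc(-c5cccc(F)c5)no4)c4ccc(Br)cc4)nn3)CC2)cc1` gives 3000 nM. Within the data shown here, the single change between them is a fluoro in place of hydrogen on an aromatic carbon, and the resulting step of a 2.3-fold lower number from compound 1 to compound 2 (0.37 log units; beyond the scatter) is modest yet beyond the scatter. Compound 2 therefore holds the lowest of the two numbers measured, with compound 1 as its nearest neighbour.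

Compound 3 `O=[N+]([O-])c1ccc(CN2CCC(n3cc(CC(OCc4cc(-c5ccccc5Br)no4)c4ccc(Br)cc4)nn3)CC2)cc1` has not been measured yet. Among the measured compounds shown here, it differs from compound 2 in one place: 2-bromophenyl in place of 3-fluorophenyl on an aromatic carbon The only measured step that bears on this is the one from compound 1 to compound 2, which placed fluoro in place of hydrogen on an aromatic carbon. That step does not test a bromine, nor a group of the 2-bromophenyl kind, so it is a weak guide. A step of similar size in either direction, or none beyond the scatter, is plausible. In this assay compound 3 is expected to give 4000 nM, with a range from 1500 nM to 10000 nM. This estimate corresponds to an expected step of a 1.3-fold higher number from compound 2 to compound 3 (0.12 log units; within the scatter).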

Compound 3, half-maximal inhibitory concentration: > 25000 nM
Compound 3 gave a limit, no number (the forecaster's own chance of this, stated with the estimate: 5%); at least 6.2-fold (0.79 log units) between middle value and limit.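

In this assay compound 3 stands at a limit of the assay and not at a number: the limit of > 25000 nM in this assay, at which 1 of the 3 values shown sits.

This gives the first sign that the aryl group on the five-membered ring can shift the read-out strongly upward, and not only downward: the change from 3-fluorophenyl to 2-bromophenyl gives an at least 8.3-fold higher number from compound 2 to compound 3 (0.92 log units; beyond the scatter), and bromo in place of hydrogen gives an at least 3.5-fold higher number from compound 1 to compound 3 (0.55 log units; beyond the scatter). Set beside a 2.3-fold lower number from compound 1 to compound 2 (0.37 log units; beyond the scatter), these steps show that a single halogen on this phenyl ring can move the number in either direction, so the effect of one such change does not predict the effect of the next.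

The compounds shown leave open whether the halogen or its place on the ring matters more, since compound 2 and compound 3 differ in both, and 2-fluorophenyl or 3-bromophenyl would separate the two. They also leave open how this ring would respond to a group that is not a halogen, such as a methoxy group, an amine or a carboxylic acid.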